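This account rests on a few compounds, and the source may have more. Where it says the series, first, only, none or still open, it means among the compounds named here.

Working notes on the series built around the core of compound 1 `CCC1(Cc2ccccc2)OS(=O)(=O)C=C1OCC(=O)OC`. In an ADME assay on HEL cells (Homo sapiens) for cytotoxicity, with a stated time of 3 days (a lower number here means that less compound is tolerated, a higher number that more compound is tolerated), compound 1 gives > 200000 nM, which is a limit of the assay and not a number. Compound 2 `CCC1(Cc2ccccc2)OS(=O)(=O)C=C1OC(c1ccccc1)c1ccccc1` carries a different ether substituent on the same core. In this assay compound 2 gives > 200000 nM, again a limit and not a number. Where compound 1 stands on the numbers shown is therefore a limit only, and the one further value shown is a limit as well: the limit of > 200000 nM in this assay, at which 2 of the 2 values shown sit. For the measured compounds named here, no step between measured compounds that differ in one place has been measured, so no step size can be read off the measured pairs.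

Compound 3 `CCC1(Cc2ccccc2)OS(=O)(=O)C=C1OCC1CCCCC1` has not yet been measured in this assay. It differs from compound 1 as follows: cyclohexyl in place of methoxycarbonyl on a saturated chain carbon bound to an oxygen on an unsaturated carbon. Given that both measured values sit at the limit, as the limit of > 200000 nM in this assay, at which 2 of the 2 values shown sit, shows, no step beyond the usual scatter is expected in either direction. The step from compound 1 to compound 3 is expected to come out as a number no higher from compound 1 to compound 3 (the limit leaves the size open). Compound 3 is estimated at 200000 nM, with a range from 100000 nM to 400000 nM.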

Compound 3, half-maximal cytotoxic concentration: > 200000 nM
Compound 3 gave a limit, no number; the forecaster's own chance of this, stated with the estimate: 85%; the middle value lies on the limit itself.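

In this assay compound 3 gives > 200000 nM, which is a limit and not a number. Compound 1 also stands at a limit, so no step from compound 1 to compound 3 can be read: the limit of > 200000 nM in this assay, at which 3 of the 3 values shown sit.

The compounds shown leave open at what concentration any of them becomes cytotoxic, and whether their ether substituents differ at all in this assay.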